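This account rests on a few compounds, and the source may have more. Where it says the series, first, only, none or still open, it means among the compounds named here.

Measured so far in a functional assay with Homo sapiens as the target; on this read-out lower numbers stand for stronger inhibition and higher numbers for weaker inhibition:
- compound 1 `CC(C)[C@H](NC(=O)COc1cccc2ccccc12)C(=O)N[C@@H](CC(=O)O)C(=O)COc1ccc(F)cc1F` gives 17600 nM
- compound 2 `CC(C)[C@H](NC(=O)COc1cccc2ccccc12)C(=O)N[C@@H](CC(=O)O)C(=O)COc1ccc(F)c(F)c1` gives 16200 nM

Compound 2 stands level with compound 1 within the scatter, so these two numbers give no ranking. Compound 3 `CC(C)[C@H](NC(=O)COc1cccc2ccccc12)C(=O)N[C@@H](CC(=O)O)C(=O)COc1c(F)c(F)cc(F)c1F` has not yet been measured. It carries 2,3,5,6-tetrafluorophenyl in place of 3,4-difluorophenyl on an oxygen on a saturated carbon and is otherwise the same as compound 2.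

Among the measured compounds shown here, only one measured step bears on this change. The step of a 1.1-fold lower number from compound 1 to compound 2 (0.04 log units; within the scatter) replaces 2,4-difluorophenyl with 3,4-difluorophenyl at the same place and stays within the scatter. For the measured compounds named here, that step leaves the number of fluorine atoms unchanged, whereas compound 3 has more of them, so no measured step covers this kind of change. The direction therefore rests on the structural change alone and is weakly supported. A modest move to a lower number is expected, and no change beyond the scatter remains possible. The expected step is a 2.0-fold lower number from compound 2 to compound 3 (0.31 log units; beyond the scatter) and is only an estimate. Compound 3 is estimated at 8000 nM with an expected range from 2000 nM to 25000 nM in this assay for now.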

Compound 3, half-maximal inhibitory concentration: 6250 nM
Estimate against measurement, compound 3: 1.3-fold (0.11 log units) above; low and high end bracket the measured number.
By their numbers in this assay, from the lowest: compound 3; then compounds 2 and 1 (each within the scatter of the next).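

In this assay, the group on the oxygen on a saturated carbon now gives a difference beyond the scatter: 2,3,5,6-tetrafluorophenyl in place of 3,4-difluorophenyl gives a 2.6-fold lower number from compound 2 to compound 3 (0.41 log units; beyond the scatter), and in place of 2,4-difluorophenyl it gives a 2.8-fold lower number from compound 1 to compound 3 (0.45 log units; beyond the scatter). Compound 1 and compound 2, which hold the same number of fluorine atoms in different arrangements, could not be ranked, so this position responds to a change in the aryl group only with the entry of the tetrafluorophenyl group, and both steps are modest. Nothing available explains this difference.

Compound 3 differs from compound 1 and compound 2 in both the number and the arrangement of its fluorine atoms, so the three compounds do not show whether the count, the arrangement or both go with the lower number. As far as these compounds go, how a plain phenyl, a pentafluorophenyl or a phenyl carrying a methoxy group would stand at this place remains open, as does whether the step would carry over to a different group on the rest of the shared core.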